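This account rests on a few compounds, and the source may have more. Where it says the series, first, only, none or still open, it means among the compounds named here.

Compound 1 `O=C(O)CCc1cccc2c1B(O)OC2`: > 100000 nM
Compound 2 `O=C(CCc1cccc2c1B(O)OC2)NCc1ccccc1`: > 100000 nM

In a functional assay on MDA-MB-231 cells (Homo sapiens) for antiproliferative activity, read by MTT assay, with a stated time of 72 h (a lower number here means a stronger inhibitor, a higher number a weaker inhibitor), compound 1 gives > 100000 nM, which is a limit of the assay and not a number. Compound 2 likewise gives > 100000 nM in this assay, again a limit rather than a measured number. Going by the values given here, compound 2 therefore stands at the edge of what this assay can report, and it shares that position with the only other value recorded (the limit of > 100000 nM in this assay, at which 2 of the 2 values shown sit). Among the compounds with values here, no step between measured compounds can be drawn here: compound 1 and compound 2 differ in more than one place, and both values are limits.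

Compound 3 `O=C(CCc1cccc2c1B(O)OC2)Nc1ccc(Br)cc1` has not yet been measured in this assay. It differs from compound 2 by 4-bromophenyl in place of benzyl on an amide-type nitrogen. Within the data shown here, with both known values sitting at a limit, there is no measured step to build on, so the step from compound 2 to compound 3 is expected to be none beyond the scatter, a number no higher from compound 2 to compound 3 (the limit leaves the size open), and compound 3 is expected to return a limit once more. Compound 3 is estimated at 100000 nM, within a range from 30000 nM to 300000 nM.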

Compound 3, half-maximal inhibitory concentration: 5300 nM
Estimate against measurement, compound 3: 19-fold (1.28 log units) above, and the stated range ends above it.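

Placing 4-bromophenyl in place of benzyl on the amide-type nitrogen gives an at least 18-fold lower number from compound 2 to compound 3 (1.27 log units; beyond the scatter) in this assay, so this position can carry a change that moves the read-out, something the earlier compounds could not show. The step is also a narrow one: the group that leaves and the group that enters have the same heavy-atom count and the same single six-membered aromatic ring of carbon only, and they differ in that a bromine enters and one carbon leaves. Compound 3 is the only compound shown with a measured number, while the other values remain limits of the assay and not numbers: the limit of > 100000 nM in this assay, at which 2 of the 3 values shown sit.

Going by these compounds alone, the single step changes two things at once, so it leaves open whether the lower number goes with the bromine or with the change from benzyl to a phenyl ring; an unsubstituted phenyl or a 4-bromobenzyl on the same nitrogen would separate the two. Going by these compounds, how far the effect extends to other groups, such as 4-chlorophenyl or 4-methoxyphenyl, also stays open.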